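The compounds below may be only part of what the source reports. "The series", "measured", "known", "first", "only" and "open" are said of these compounds alone.

Measured compounds:

Compound 1 `O=C(COc1cccc(Cl)c1)NC1CCN(Cc2ccc3[nH]ccc3c2)CC1`: 2340 nM
Compound 2 `O=C(COc1cccc(Cl)c1)NC1CCN(Cc2ccn(-c3ccccc3)c2)CC1`: 710 nM

Both compounds share the same core and were tested in an assay on HEK293 cells for displacement of a labelled ligand from melanin-concentrating hormone receptor 1 (Homo sapiens); on this read-out higher numbers stand for weaker inhibition and lower numbers for stronger inhibition. In this assay compound 1 gives 2340 nM, while compound 2 gives 710 nM. Compound 2 thus has the lower of the two numbers, and the gap to compound 1 is larger than the usual scatter of repeated measurements, so compound 2 is the stronger of the pair on this read-out.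

Compound 3 `O=C(COc1cccc(Cl)c1)NC1CCN(Cc2ccn(C3CCCC3)c2)CC1` has not yet been measured. It differs from compound 2 in one place: cyclopentyl in place of phenyl on an aromatic nitrogen. Both groups that are exchanged carry no hydrogen-bond donors or acceptors and no charge, so the change is one of ring type and size rather than of polarity. Within the data shown here, no pair of measured compounds shows this kind of exchange, so there is nothing to anchor the direction of the step.

For compound 3 the expected step from compound 2 is a 1.5-fold higher number from compound 2 to compound 3 (0.19 log units; within the scatter), with a modest weakening as the more likely outcome and no change beyond the scatter well within reach. Compound 3 is therefore estimated to give about 1100 nM in this assay, within a range of 350 nM to 3500 nM.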

Compound 3, half-maximal inhibitory concentration: > 33000 nM
Compound 3: only a limit was reported (the forecaster's own chance of this, stated with the estimate: 5%); at least 30-fold (1.47 log units) between middle value and limit.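

On the aromatic nitrogen of this five-membered aromatic ring, the exchange of phenyl for cyclopentyl in this assay gives an at least 46-fold higher number from compound 2 to compound 3 (1.66 log units; beyond the scatter). This position therefore responds strongly to the type of ring it carries, even though neither group has hydrogen-bond donors, hydrogen-bond acceptors or a net charge, so these counts alone do not predict the outcome here. Compound 3 reached only a limit of the assay and not a number, so the true size of the step remains unknown and the printed step is only its lower bound: the limit of > 33000 nM in this assay, at which 1 of the 3 values shown sits.

Ring size and aromatic character change together in this single exchange, and the compounds shown cannot tell apart their contributions. From the compounds shown here alone, it remains open whether cyclohexyl, which would keep a six-membered ring without an aromatic one, would behave more like phenyl or more like cyclopentyl, and whether a pyridyl ring, with a nitrogen in the aromatic ring, would be accepted at this position.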